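This account rests on a few compounds, and the source may have more. Where it says the series, first, only, none or still open, it means among the compounds named here.

Three members of the series have numbers in a functional assay on HepG2 cells (Homo sapiens) for cytotoxicity, read by MTT assay, with a stated time of 48 h; a higher number here means a weaker inhibitor, a lower number a stronger inhibitor: compound 1 `Cc1ncc([N+](=O)[O-])n1CCSc1nnc(-c2ccccc2[N+](=O)[O-])o1` gives 700 nM, compound 2 `Cc1ncc([N+](=O)[O-])n1CCSc1nnc(-c2ccccc2F)o1` gives 3700 nM, and compound 3 `COc1ccc(-c2nnc(SCCn3c([N+](=O)[O-])cnc3C)o2)c(O)c1` gives 11000 nM. Compound 2 stands second highest of the three, with compound 3 nearest and compound 1 furthest. Among the compounds with values here, the one single-point step recorded on the aromatic ring of the shared core, a 5.3-fold higher number from compound 1 to compound 2 (0.72 log units; beyond the scatter), is modest. Compound 4 `Cc1ncc([N+](=O)[O-])n1CCSc1nnc(-c2ccccn2)o1` differs from compound 2 by pyridin-2-yl in place of 2-fluorophenyl on an aromatic carbon. Within the data shown here, no measured step exchanges this ring itself, so the expected step of a 1.4-fold higher number from compound 2 to compound 4 (0.13 log units; within the scatter) is uncertain and is set near no change in this assay. Compound 4 is therefore estimated at 5000 nM, within 1500 nM to 15000 nM.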

Compound 4, half-maximal inhibitory concentration: 20200 nM
For compound 4 the middle estimate is 4.0-fold (0.61 log units) below the measured one; measured number above the stated range.
By their numbers in this assay, from the lowest: compound 1; then compound 2; then compounds 3 and 4 (each within the scatter of the next).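

In this assay, the earlier step changed only a group on the phenyl ring, whereas replacing 2-fluorophenyl with pyridin-2-yl changes the ring itself and gives a 5.5-fold higher number from compound 2 to compound 4 (0.74 log units; beyond the scatter). This position of the shared core therefore responds to a ring exchange as well as to a substituent exchange, and here the number rises. No measurement bears on the reason for this step.

A plain phenyl ring would separate the share of the fluorine leaving from that of the ring nitrogen entering. From the compounds shown here alone, whether pyridin-2-yl carrying an amine would give a similar number remains open.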